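The source may hold more compounds than are shown below. What is called first, only, known or untested is meant among the compounds shown, and "the series" means these compounds.

Compound 1 `CC(C)[C@H](NC(=O)c1ccccc1Br)C(=O)N1CCC[C@H]1C(=O)N[C@@H](CCCNC(=N)N)C(=O)CF` carries a 2-bromophenyl group on a carbonyl carbon. In a functional assay on OCI-Ly3 cells (Homo sapiens) for inhibition, read by CellTiter-Glo, with stated times of 48 h and 96 h (on this read-out lower numbers stand for stronger inhibition of growth and higher numbers for weaker inhibition of growth), compound 1 gives 4240 nM, the highest number of the three measured compounds. Compound 2 `CC(C)[C@H](NC(=O)c1ccc(Br)cc1)C(=O)N1CCC[C@H]1C(=O)N[C@@H](CCCNC(=N)N)C(=O)CF` gives 130 nM and compound 3 `CC(C)[C@H](NC(=O)c1ccc(Cl)cc1)C(=O)N1CCC[C@H]1C(=O)N[C@@H](CCCNC(=N)N)C(=O)CF` gives 1240 nM. The measured steps of a 33-fold lower number from compound 1 to compound 2 (1.51 log units; beyond the scatter) and a 3.4-fold lower number from compound 1 to compound 3 (0.53 log units; beyond the scatter) show that this part of the molecule matters, and a 9.5-fold higher number from compound 2 to compound 3 (0.98 log units; beyond the scatter) shows that even the halogen type counts. Compound 4 `CC(C)[C@H](NC(=O)Nc1ccccc1)C(=O)N1CCC[C@H]1C(=O)N[C@@H](CCCNC(=N)N)C(=O)CF` differs from compound 1 by anilino in place of 2-bromophenyl on a carbonyl carbon, turning the amide into a urea. Among the measured compounds shown here, no measured step covers this change, so no direction is firmly indicated. Compound 4 is estimated at 3500 nM, between 700 nM and 17000 nM, which would mean an expected step of a 1.2-fold lower number from compound 1 to compound 4 (0.08 log units; within the scatter).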

Compound 4, concentration for 50% growth inhibition: 1520 nM
For compound 4 the middle estimate is 2.3-fold (0.36 log units) above the measured one, and the stated range covers the measured number.
By their numbers in this assay, from the lowest: compound 2; then compounds 3 and 4 (each within the scatter of the next); then compound 1.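

Replacing the amide with a urea does not cost activity relative to the 2-bromophenyl compound: the anilino group gives a 2.8-fold lower number from compound 1 to compound 4 (0.45 log units; beyond the scatter). It stays level with the 4-chlorophenyl group, with a 1.2-fold higher number from compound 3 to compound 4 (0.09 log units; within the scatter), but falls well short of the 4-bromophenyl group, with a 12-fold higher number from compound 2 to compound 4 (1.07 log units; beyond the scatter). No measured evidence explains these differences. On these data alone, it remains open whether a bromine on the anilino ring, as in 4-bromoanilino, would bring the same gain it brings on the phenyl amide. A longer link such as benzylamino is also untested here.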